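The source may hold more compounds than are shown below. What is called first, only, known or untested is meant among the compounds shown, and "the series" means these compounds.

Measured so far:
compound 1, `O=C(Nc1cc(C(F)(F)F)cc(C(F)(F)F)c1)c1cc(Br)ccc1O`: 350 nM
compound 2, `O=C(Nc1cc(C(F)(F)F)cc(C(F)(F)F)c1)c1cc(Br)c(-c2ccccc2)cc1O`: 680 nM

In a functional assay on Jurkat cells (Homo sapiens) for cytotoxicity, read by luminescence and CellTiter-Glo, with a stated time of 3 days (on this read-out higher numbers stand for weaker inhibition and lower numbers for stronger inhibition), compound 1 gives 350 nM and compound 2 gives 680 nM. Among the measured compounds shown here, the only step measured between them, a 1.9-fold higher number from compound 1 to compound 2 (0.29 log units; within the scatter), is phenyl in place of hydrogen on an aromatic carbon, and it lies within the usual scatter, so the two numbers sit together and neither compound can be called the stronger of the pair.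

Compound 3, `O=C(Nc1cc(C(F)(F)F)cc(C(F)(F)F)c1)c1cc(F)ccc1O`, has not yet been tested in this assay. It differs from compound 1 by fluoro in place of bromo on an aromatic carbon: the bromo leaves and a fluoro enters on an aromatic carbon of a six-membered aromatic ring of carbon only, para to a hydroxy group. For the measured compounds named here, no measured pair shows one halogen exchanged for another; the one step on record, a 1.9-fold higher number from compound 1 to compound 2 (0.29 log units; within the scatter), concerns a different place and is within the scatter, so it offers no guide here. Without a precedent, the expected step for compound 3 is a 2.9-fold higher number from compound 1 to compound 3 (0.46 log units; beyond the scatter), leaning toward a higher number but with wide uncertainty. Compound 3 is therefore estimated at 1000 nM, with a range from 300 nM to 3500 nM.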

Compound 3, half-maximal inhibitory concentration: 500 nM
Compound 3: middle estimate off by 2.0-fold (0.30 log units), on the high side; the range from low to high includes it.
By their numbers in this assay, from the lowest: compounds 1, 3 and 2 (each within the scatter of the next).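

Swapping bromo for fluoro on this aromatic carbon, para to a hydroxy group, gives a 1.4-fold higher number from compound 1 to compound 3 (0.15 log units; within the scatter) in this assay, so the two numbers sit together and neither compound can be called the stronger. Among the compounds shown here, the earlier pair changed a different carbon, which makes this the first reading at the bromo position itself, and it shows that in this assay the core of compound 1 keeps a similar number with either of these two halogens there. Nothing at hand explains why the two halogens read alike.

The compounds shown compare only bromo and fluoro at this position, so it remains open whether a group of another kind, such as a methoxy group, an amine or a carboxylic acid, would give a similar number or a clearly different one. From the compounds shown here alone, it is also open how the number would respond to plain hydrogen on this carbon, which would show whether a halogen is needed there at all.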